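Relocating the Methoxy Group on the Anilide Ring

A few compounds are considered here, and "the series" means these few. Any claim that something is new, unique, unknown or untested is made for them only; others in the source may bear on it.

Going by the values given here, compound 2 `COc1ccc(C)cc1NC(=O)CSc1nnc(-c2ccoc2C)n1Cc1ccco1` is the only compound with a numerical result in a functional assay on CHO cells for antagonist activity at Orexin receptor type 2 (Homo sapiens), read by FLIPR and calcium flux (a higher number here means a weaker inhibitor, a lower number a stronger inhibitor), where compound 2 gives 15.9 nM. Compound 1 `Cc1cccc(C)c1NC(=O)CSc1nnc(-c2ccoc2C)n1Cc1ccco1` reaches only a limit in this assay, namely > 15800 nM. Among the compounds with values here, the single measured step, an at least 990-fold lower number from compound 1 to compound 2 (2.99 log units; beyond the scatter), shows how strongly this assay responds to the aryl group on the amide-type nitrogen, though one end of it is a limit (the limit of > 15800 nM in this assay, at which 1 of the 2 values shown sits). Compound 3 `COc1ccc(NC(=O)CSc2nnc(-c3ccoc3C)n2Cc2ccco2)cc1` carries the change (4-methoxyphenyl in place of 2-methoxy-5-methylphenyl on an amide-type nitrogen). Within the data shown here, no measured step covers this change directly. Compound 3 is expected to be somewhat weaker, a step of a 10-fold higher number from compound 2 to compound 3 (1.00 log units; beyond the scatter), with an estimated 160 nM, ranging from 20 nM to 3000 nM.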

Compound 3, inhibition constant: 200 nM
Compound 3: the middle estimate sits 1.3-fold (0.10 log units) below what was measured; low and high end bracket the measured number.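

In this assay, the change to 4-methoxyphenyl on the amide-type nitrogen gives a 13-fold higher number from compound 2 to compound 3 (1.10 log units; beyond the scatter) and so falls short of 2-methoxy-5-methylphenyl, yet activity is far from lost. Against 2,6-dimethylphenyl, the same group gives an at least 79-fold lower number from compound 1 to compound 3 (1.89 log units; beyond the scatter) as a step that still stands out clearly. The value for compound 1 at one end of that step is a limit: the limit of > 15800 nM in this assay, at which 1 of the 3 values shown sits.

From the compounds shown here alone, the methoxy group moves and the methyl group leaves in one change, so which of the two carries the step stays open. Going by these compounds, how an ethoxy group or a chlorine atom on this ring would read also stays open.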